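A few compounds are considered here, and "the series" means these few. Any claim that something is new, unique, unknown or untested is made for them only; others in the source may bear on it.

In an ADME assay on microsomes from liver (Homo sapiens) for metabolic stability, read by LC-MS, tested at 1 uM (a higher number here means that the compound lasts longer, a lower number that the compound disappears faster), compound 1 (`O=C(Nc1ccc(F)c(-c2nc3ncccc3o2)c1)c1ccoc1`) gives 0.183 h. For the measured compounds named here, only one other compound has a number so far: compound 2 (`Cc1ccoc1C(=O)Nc1ccc(F)c(-c2nc3ncccc3o2)c1`) gives 0.15 h, and the two lie within the scatter of each other. Compound 3 (`Cc1ccc(NC(=O)c2ccoc2)cc1-c1nc2ncccc2o1`) keeps the furan-3-yl carbonyl of compound 1 and differs by one swap: methyl in place of fluoro on an aromatic carbon. Going by the values given here, the single measured step, a 1.2-fold lower number from compound 1 to compound 2 (0.09 log units; within the scatter), is small, but it alters the group on the carbonyl carbon, so it says little about a swap on the aromatic carbon. Among the compounds with values here, no measured pair tests methyl in place of fluoro, so the data do not fix the size of this step. The expectation is therefore only a slight move towards a lower number, no larger than the scatter. The expected step is a 1.3-fold lower number from compound 1 to compound 3 (0.12 log units; within the scatter). In this assay, compound 3 is estimated at 0.14 h, with an expected range from 0.07 h to 0.26 h.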

Compound 3, half-life in the Homo sapiens assay: 0.167 h
Compound 3: the middle estimate sits 1.2-fold (0.08 log units) below what was measured; measured number inside the range.
By their numbers in the Homo sapiens assay, from the lowest: compounds 2, 3 and 1 (each within the scatter of the next).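

For the compounds shown here, until now, no measured pair tested this aromatic carbon; methyl in place of fluoro here gives a 1.1-fold lower number from compound 1 to compound 3 (0.04 log units; within the scatter), so in this pair the swap leaves the half-life indistinguishable. In a physicochemical assay for solubility, read by nephelometry, in phosphate buffer, measured as kinetic solubility, at pH 2 (a lower number here means a less soluble compound, a higher number a more soluble compound), the same swap gives no change at the digits printed from compound 1 to compound 3 (within the scatter), with compound 1 at 12.5 ug/mL and compound 3 at 12.5 ug/mL, so neither read-out separates the two groups in this pair. Nothing available explains this result.

The compounds shown leave open whether an amine, a carboxylic acid or a longer chain on this carbon would shift either read-out beyond the scatter. Going by these compounds, it also remains open whether methyl in place of fluoro would act the same way alongside the 3-methylfuran-2-yl group of compound 2.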